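The compounds below may be only part of what the source reports. "The series", "measured", "known", "first", "only" and "open" are said of these compounds alone.

Compound 1 `CC(Sc1nnc(-c2ccncc2)s1)C(=O)NCc1ccc(Cl)cc1`: "not determined" (no result reported)
Compound 2 `CC(CSc1nnc(-c2ccncc2)s1)C(=O)Nc1ccc(Cl)cc1`: > 50000 nM
Compound 3 `CC(CSc1nnc(-c2ccncc2)s1)C(=O)NCc1ccccc1`: > 50000 nM

In an ADME assay on BHK-21 cells (Mesocricetus auratus) for cytotoxicity, with a stated time of 3 days (on this read-out higher numbers stand for lower toxicity in this test and lower numbers for higher toxicity in this test), compound 1 has no single number, its entry being recorded as "not determined" (no result reported). Compound 2 reaches only the limit of this assay, > 50000 nM. Compound 3 likewise reaches only a limit, > 50000 nM. Among the compounds with values here, the step that the two limits leave unreadable from compound 2 to compound 3 therefore cannot be read, and the only evidence is the limit of > 50000 nM in this assay, at which 2 of the 3 values shown sit.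

Compound 4 `CC(Sc1nnc(-c2ccncc2)s1)C(=O)Nc1ccc(Cl)cc1` differs from compound 1 by 4-chlorophenyl in place of 4-chlorobenzyl on an amide-type nitrogen. Within the data shown here, no measured step bears directly on this change, and no step in this assay beyond the scatter has been seen in either direction. On that basis compound 4 is expected to sit at or beyond the limit as well, estimated at 60000 nM with a range from 20000 nM to 200000 nM.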

Compound 4, half-maximal cytotoxic concentration: > 50000 nM
Compound 4: no number, only a limit (the forecaster's own chance of this, stated with the estimate: 80%); the middle value is on the limit's open side.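

No new step can be read between compound 1 and compound 4: compound 1 has no number, and compound 4 gives only a limit in this assay. The compounds shown leave open at what concentration, if any, compound 2, compound 3 or compound 4 would harm these cells.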